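The compounds below may be only part of what the source reports. "The series", "measured", "known", "first", "only" and "open" are said of these compounds alone.

In a functional assay on MT4 cells (Homo sapiens) for cytotoxicity (a higher number here means a weaker inhibitor, a lower number a stronger inhibitor), compound 1 `N#Cc1c(N)cccc1Sc1ccccc1` gives 168000 nM and compound 3 `N#Cc1c(N)cccc1Sc1ccccc1Br` gives 41000 nM. Compound 2 `COc1cccc(Sc2cccc(N)c2C#N)c1` reads > 200000 nM, which is a limit of the assay and not a number. Among the measured compounds shown here, that makes it the one limit among the values so far: the limit of > 200000 nM in this assay, at which 1 of the 3 values shown sits. Compound 4 `N#Cc1c(N)cccc1Sc1cccc(Br)c1` carries bromo in place of methoxy on an aromatic carbon. For the measured compounds named here, two measured steps bear on this change. Adding methoxy gave an at least 1.1-fold higher number from compound 1 to compound 2 (0.07 log units; that floor lies within the scatter). Adding bromo gave a 4.1-fold lower number from compound 1 to compound 3 (0.61 log units; beyond the scatter), though at another place on the ring. A lower number is therefore expected in this assay, and the estimated step is an at least 3.3-fold lower number from compound 2 to compound 4 (0.52 log units; beyond the scatter). Compound 4 is expected at 60000 nM, within an estimated range of 22000 nM to 170000 nM.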

Compound 4, half-maximal inhibitory concentration: 53000 nM
For compound 4 the middle estimate is 1.1-fold (0.05 log units) above the measured one; measured number inside the range.
By their numbers in this assay, from the lowest: compounds 3 and 4 (each within the scatter of the next); then compound 1. At a limit, above all of these: compound 2.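

Bromo in place of hydrogen on this aromatic carbon, meta to a large group, gives a 3.2-fold lower number from compound 1 to compound 4 (0.50 log units; beyond the scatter), so the lower number seen with bromo is not confined to the place it holds in compound 3; compound 3 and compound 4 lie within the scatter of each other. Bromo in place of methoxy gives an at least 3.7-fold lower number from compound 2 to compound 4 (0.57 log units; beyond the scatter), which is only a floor. Compound 2 stands at a limit and not at a number: the limit of > 200000 nM in this assay, at which 1 of the 4 values shown sits.

Going by these compounds, whether chloro or an amine on this carbon would lower the number as bromo does stays open. On these data alone, the full size of the step from methoxy to bromo also stays open.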